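The compounds below may be only part of what the source reports. "The series", "measured", "known", "first", "only" and "open" are said of these compounds alone.

Measured so far in a functional assay for inhibition of sodium/hydrogen exchanger (Oryctolagus cuniculus); on this read-out higher numbers stand for weaker inhibition and lower numbers for stronger inhibition:
compound 1, `CS(=O)(=O)c1cc(C(=O)N=C(N)N)c(F)cc1F`: 630 nM
compound 2, `CCC(C)c1cc(C)c(C(=O)N=C(N)N)cc1S(C)(=O)=O`: 8 nM
compound 3, `Cc1cc(-c2cc(C(F)(F)F)cc(C(F)(F)F)c2)c(S(C)(=O)=O)cc1C(=O)N=C(N)N`: 2800 nM

Compound 2 stands lowest of the three numbers in this assay. Its nearest neighbour is compound 1, whose number lies higher by a gap beyond the scatter; the furthest is compound 3, higher again by a gap well beyond the scatter. Compound 2 is therefore the strongest inhibitor of the three measured here.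

Compound 4, `Cc1cc(Sc2ccncc2)c(S(C)(=O)=O)cc1C(=O)N=C(N)N`, is not yet measured. It differs from compound 2 in one place: (pyridin-4-yl)sulfanyl in place of sec-butyl on an aromatic carbon

For the measured compounds named here, no step between measured compounds covers this change, so the expectation rests on the spread seen so far. Going by the values given here, the only other compound with an aromatic ring entering the core beyond the shared substituents, compound 3, gives 2800 nM, far above compound 2. A ring-bearing group at this position is therefore expected to raise the number rather than lower it, though the entering group here is smaller than that of compound 3 and the step from compound 2 to compound 4 is expected to be moderate, a 6.3-fold higher number from compound 2 to compound 4 (0.80 log units; beyond the scatter), in the direction of weaker inhibition. Compound 4 is estimated at 50 nM, with a range from 8 nM to 300 nM.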

Compound 4, half-maximal inhibitory concentration: 13 nM
For compound 4 the middle estimate is 3.8-fold (0.59 log units) above the measured one, within the range that was stated.
By their numbers in this assay, from the lowest: compounds 2 and 4 (each within the scatter of the next); then compound 1; then compound 3.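

In this assay the exchange of sec-butyl for (pyridin-4-yl)sulfanyl on this aromatic carbon gives a 1.6-fold higher number from compound 2 to compound 4 (0.21 log units; within the scatter) so the two groups are not separated by this read-out, although the entering group is larger, contains a six-membered aromatic ring with one hetero atom and has hydrogen-bond acceptors that sec-butyl lacks. Before this result the only ring-bearing group at this place was that of compound 3 at 2800 nM whereas compound 4 at 13 nM carries an aromatic ring and still lies within the scatter of compound 2, so a ring here does not by itself go with a high number, and compound 3 remains the case against a general tolerance of rings. No measurement at hand bears on the cause of this result.

The compounds shown leave open whether the sulfur link or the ring nitrogen matters, a question that a phenylsulfanyl group, a directly attached pyridin-4-yl group or an oxygen link could address. Also open, from the compounds shown here alone, is how this place responds to a group such as an amine or a carboxylic acid.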